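A few compounds are considered here, and "the series" means these few. Any claim that something is new, unique, unknown or untested is made for them only; others in the source may bear on it.

Measured compounds: compound 1 `CCNC1=NS(=O)(=O)c2cc(F)ccc2N1` and compound 2 `CCCNC1=NS(=O)(=O)c2cc(F)ccc2N1`.

In a functional assay (aorta) with Rattus norvegicus as the target (a lower number here means that less compound is needed, a higher number that more compound is needed for the effect), compound 1 gives only a limit, > 300 uM. In this assay compound 2 gives 166 uM. The step of an at least 1.8-fold lower number from compound 1 to compound 2 (0.25 log units; that floor lies within the scatter) concerns the amine chain. Compound 3 `CCNC1=NS(=O)(=O)c2cc(Br)ccc2N1` differs from compound 1 by bromo in place of fluoro on an aromatic carbon. For the measured compounds named here, no measured step touches the fluoro, so neither measured step bears on this change, and compound 1 stands only at a limit (the limit of > 300 uM in this assay, at which 1 of the 2 values shown sits). No step beyond the scatter is expected. Compound 3 is expected at 250 uM, with a range from 90 uM to 700 uM. The expected step is an at least 1.2-fold lower number from compound 1 to compound 3 (0.07 log units; that floor lies within the scatter).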

Compound 3, concentration for half-maximal effect: 6.2 uM
Compound 3: the middle estimate sits 40-fold (1.61 log units) above what was measured; the whole stated range lies above it.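

Bromo in place of fluoro on this aromatic carbon gives the first step in the series that clearly exceeds the scatter in this assay: an at least 48-fold lower number from compound 1 to compound 3 (1.68 log units; beyond the scatter). The earlier step on the amine chain has a floor within the scatter, so this ring position is the only place shown where a single change clearly lowers the number. The step is only a floor, as compound 1 stands at a limit: the limit of > 300 uM in this assay, at which 1 of the 3 values shown sits.

On these data alone, whether chloro, iodo or methyl at the same carbon would lower the number as bromo does stays open. Also open, as far as these compounds go, is whether bromo combined with the longer amine chain of compound 2 would lower it further.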